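This account rests on a few compounds, and the source may have more. Where it says the series, first, only, none or still open, it means among the compounds named here.

Working notes on the series. The compounds share the core of compound 1 `CN(C)c1ccc(NC(=O)Nc2cccc(CNc3nccnc3Cl)c2)cc1` and differ in the group carried on an amide-type nitrogen. In a functional assay on HepG2 cells (Homo sapiens) for antiproliferative activity, read by MTT assay, with a stated time of 48 h (a higher number here means a weaker inhibitor, a lower number a stronger inhibitor), compound 1 gives > 40000 nM, which is a limit of the assay and not a number. Compound 2 `O=C(Nc1cccc(CNc2nccnc2Cl)c1)Nc1ccc(F)c(Cl)c1` has 3-chloro-4-fluorophenyl in place of 4-(dimethylamino)phenyl on an amide-type nitrogen, and in this assay compound 2 gives 6750 nM. For the measured compounds named here, the step of an at least 5.9-fold lower number from compound 1 to compound 2 (0.77 log units; beyond the scatter) is the only measured step in the set, and it sets no more than a floor because the limit of > 40000 nM in this assay, at which 1 of the 2 values shown sits, caps what is known of compound 1. Compound 3 `Cc1ccc(NC(=O)Nc2cccc(CNc3nccnc3Cl)c2)cc1` differs from compound 1 as follows: methyl in place of dimethylamino on an aromatic carbon. Going by the values given here, the single measured step bears on this change only in that it too removes the dimethylamino group; whether a methyl alone moves the number cannot be separated from a step that pairs that removal with entry of 3-chloro-4-fluorophenyl. A modest lowering is expected, with wide uncertainty, and a limit result remains a real possibility. For compound 3 the expected step is an at least 2.0-fold lower number from compound 1 to compound 3 (0.30 log units; that floor lies within the scatter). The estimate for compound 3 in this assay is 20000 nM, between 6000 nM and 60000 nM.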

Compound 3, half-maximal inhibitory concentration: 11500 nM
For compound 3 the middle estimate is 1.7-fold (0.24 log units) above the measured one; the measured number falls inside the stated range.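

In this assay, the change from dimethylamino to methyl on the aromatic carbon, with nothing else altered, gives an at least 3.4-fold lower number from compound 1 to compound 3 (0.54 log units; beyond the scatter), so the lowering no longer depends on a step that also brings in 3-chloro-4-fluorophenyl. On these data alone, the true size of this step stays unknown, because the value of compound 1 is a limit of the assay and not a number: the limit of > 40000 nM in this assay, at which 1 of the 3 values shown sits. With a 1.7-fold higher number from compound 2 to compound 3 (0.23 log units; within the scatter), 4-methylphenyl and 3-chloro-4-fluorophenyl on the amide-type nitrogen cannot be told apart in this assay, so the chlorine and fluorine are not needed for a value in this range.

The compounds shown do not separate the loss of dimethylamino from the entry of methyl, since both occur together in the only step at this carbon; a plain hydrogen on that carbon would speak to that question. As far as these compounds go, how a methoxy group, a primary amine or a longer alkyl chain on the same carbon would compare with methyl also stays open, as does whether any group there moves the number beyond the scatter from that of compound 3.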